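Pyrazin-2-yl in Place of Cyclohexyl: An Expected Shift

The source may hold more compounds than are shown below. What is called first, only, known or untested is meant among the compounds shown, and "the series" means these compounds.

Compound 1 `Cc1cc(C(=O)NCCCCCCS)[nH]n1`: "not determined" (no result reported)
Compound 2 `O=C(NCCCCCCS)c1cc(-c2c[nH]c3ccccc23)n[nH]1`: 33 nM
Compound 3 `O=C(NCCCCCCS)c1cc(C2CCCCC2)n[nH]1`: 241 nM

In an assay on isolated protein for inhibition of protein deacetylase HDAC6 (Homo sapiens), read by fluorescence, with stated times of 15 min and 60 min (on this read-out higher numbers stand for weaker inhibition and lower numbers for stronger inhibition), compound 3 gives 241 nM, the highest of the two numbers available. Compound 2 gives 33 nM, and this gap lies beyond the usual scatter, while compound 1 has no result at all. Compound 4 `O=C(NCCCCCCS)c1cc(-c2cnccn2)n[nH]1` differs from compound 3 in one place: pyrazin-2-yl in place of cyclohexyl on an aromatic carbon. Among the compounds with values here, no step between measured compounds is available for comparison, so the two known values are the only guide. The step from compound 3 to compound 4 is estimated at a 2.4-fold lower number from compound 3 to compound 4 (0.38 log units; beyond the scatter), toward stronger inhibition, because compound 2 gives 33 nM with a six-membered aromatic ring in this position. Compound 4 is therefore expected to give about 100 nM, within a range of 30 nM to 330 nM.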

Compound 4, half-maximal inhibitory concentration: 22 nM
Estimate against measurement, compound 4: 4.5-fold (0.66 log units) above; measured number outside the range, below it.
By their numbers in this assay, from the lowest: compounds 4 and 2 (each within the scatter of the next); then compound 3.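

Replacing cyclohexyl with pyrazin-2-yl, a group with the same number of heavy atoms, gives an 11-fold lower number from compound 3 to compound 4 (1.04 log units; beyond the scatter) in this assay, so this position responds strongly to the ring it carries. Compound 4 at 22 nM and compound 2 at 33 nM lie within the scatter of each other, and both carry an aromatic group here. Nothing measured here accounts for the size of this step.

On these data alone, whether phenyl, which has no ring nitrogen, would match pyrazin-2-yl remains open. So does whether an amine on that ring would keep this level of inhibition.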